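Swapping butyl for 4-aminophenyl on a triple-bonded carbon

The source may hold more compounds than are shown below. What is called first, only, known or untested is meant among the compounds shown, and "the series" means these compounds.

Values in a functional assay on SK-MEL-147 cells (Homo sapiens) for cytotoxicity, read by MTT assay, with a stated time of 24 h; on this read-out lower numbers stand for an effect already at smaller amounts and higher numbers for an effect only at larger amounts of compound:
- Compound 1 `CCOC(=O)c1cc([Se]Cc2ccccc2)c2cc(OC)ccc2n1`: 40700 nM
- Compound 2 `CCCCC#Cc1cc(C(=O)OCC)nc2ccc(OC)cc12`: 7200 nM
- Compound 3 `CCOC(=O)c1cc([Se]c2ccc(F)cc2)c2cc(OC)ccc2n1`: > 150000 nM (a limit, not a number)

Compound 2 has the lower of the two actual numbers. The gap between those two numbers is a 5.7-fold lower number from compound 1 to compound 2 (0.75 log units; beyond the scatter). The entry for compound 3 is only a limit of the assay.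

The unmeasured compound 4 `CCOC(=O)c1cc(C#Cc2ccc(N)cc2)c2cc(OC)ccc2n1` keeps the shared core of compound 2 and changes one group: 4-aminophenyl in place of butyl on a triple-bonded carbon. In words, 4-aminophenyl sits in place of butyl on a triple-bonded carbon. Within the data shown here, no measured step makes this exact change, so the evidence is indirect. Compound 2 has no ring in its changing group, whereas compound 1 and compound 3 both have a six-membered aromatic ring there. The ring-free compound holds the lowest number in this small set, as a 5.7-fold lower number from compound 1 to compound 2 (0.75 log units; beyond the scatter) and an at least 20-fold higher number from compound 2 to compound 3 (1.31 log units; beyond the scatter) show. The step of an at least 3.6-fold higher number from compound 1 to compound 3 (0.56 log units; beyond the scatter) adds that 4-fluorophenyl in place of benzyl on a selenium also raised the number.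

Among the measured compounds shown here, with only three compounds, and none sharing the new group, a modest rise in this assay is expected, with wide uncertainty. The estimated step is a 2.5-fold higher number from compound 2 to compound 4 (0.40 log units; beyond the scatter). For compound 4 the expected value is 18000 nM, within an estimated range of 4000 nM to 80000 nM.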

Compound 4, half-maximal effective concentration: 8800 nM
Compound 4: the middle estimate sits 2.0-fold (0.31 log units) above what was measured, and the stated range covers the measured number.
By their numbers in this assay, from the lowest: compounds 2 and 4 (each within the scatter of the next); then compound 1. At a limit, above all of these: compound 3.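

On the triple-bonded carbon, a ring can take the place of a plain chain without moving the number beyond the scatter: in this assay the exchange of butyl for 4-aminophenyl gives a 1.2-fold higher number from compound 2 to compound 4 (0.09 log units; within the scatter). Until now, the compounds with an aromatic ring in the changing group, compound 1 and compound 3, held that ring on a selenium, so the ring and its link could not be told apart, and the ring-free compound 2 simply had the lowest number. Compound 4 goes against that reading, since it has an aromatic ring on the triple bond and still stays within the scatter of compound 2, although no measurement shown gives a property of either group that would account for this.

Going by these compounds, it remains open whether the amine matters or the ring alone is enough, which plain phenyl or a 4-hydroxyphenyl group at this place would help to separate. Also open, on these data alone, is how a chain longer than butyl, or a carboxylic acid on the ring, would read in this assay.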